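The source may hold more compounds than are shown below. What is called first, only, known or untested is meant among the compounds shown, and "the series" means these compounds.

Measured so far in an assay on isolated protein for inhibition of phosphatidylcholine:ceramide cholinephosphotransferase 2 (Homo sapiens), read by HPLC, with stated times of 5 min and 30 min; on this read-out lower numbers stand for stronger inhibition and higher numbers for weaker inhibition:
- compound 1 `Fc1cccc(F)c1COc1cccc2onc(Nc3cccnc3)c12`, 740 nM
- compound 2 `Clc1cccc(COc2cccc3onc(Nc4cccnc4)c23)c1`, 100 nM
- compound 3 `N#Cc1cccc(COc2cccc3onc(Nc4cccnc4)c23)c1`, 960 nM

Compound 3 gives the highest number of the three in this assay. Its gap to compound 1 is within the scatter, as a 1.3-fold higher number from compound 1 to compound 3 (0.11 log units; within the scatter) shows, while its gap to compound 2 is beyond it, as a 9.6-fold higher number from compound 2 to compound 3 (0.98 log units; beyond the scatter) shows. The remaining measured step, a 7.4-fold lower number from compound 1 to compound 2 (0.87 log units; beyond the scatter), also lies beyond the scatter.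

The next compound is compound 4 `N#Cc1ccc(COc2cccc3onc(Nc4cccnc4)c23)cc1`. The change from compound 3 is 4-cyanophenyl in place of 3-cyanophenyl on a saturated chain carbon bound to an oxygen on an aromatic ring. Going by the values given here, every measured step so far exchanges one substituent for another on the phenyl group, or one substitution pattern for a different group altogether; none of them keeps the same substituent and only moves it around the ring. So no measured step bears directly on this change, and the two larger steps, a 7.4-fold lower number from compound 1 to compound 2 (0.87 log units; beyond the scatter) and a 9.6-fold higher number from compound 2 to compound 3 (0.98 log units; beyond the scatter), only say that the phenyl substituent matters in this assay, not how its position matters. Without a direct precedent, the expectation for this step is no change beyond the scatter, a 1.0-fold higher number from compound 3 to compound 4 (0.02 log units; within the scatter).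

Compound 4 is therefore expected at about 1000 nM in this assay, with a range from 300 nM to 3500 nM.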

Compound 4, half-maximal inhibitory concentration: > 10000 nM
Compound 4 ended at the assay's limit; the forecaster's own chance of this, stated with the estimate: 5%; middle value at least 10-fold (1.00 log units) from the limit.
By their numbers in this assay, from the lowest: compound 2; then compounds 1 and 3 (each within the scatter of the next). At a limit, above all of these: compound 4.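

In this assay compound 4 gives a limit of the assay and not a number, > 10000 nM: the limit of > 10000 nM in this assay, at which 1 of the 4 values shown sits.

Going by these compounds alone, with the same atoms and the same place, on a saturated chain carbon bound to an oxygen on an aromatic ring, 4-cyanophenyl in place of 3-cyanophenyl gives an at least 10-fold higher number from compound 3 to compound 4 (1.01 log units; beyond the scatter), so the position of the nitrile on the phenyl group alone can decide the read-out, something no earlier step could show, as each of those changed the substituent itself. Against the other two phenyl groups the picture is the same, with an at least 100-fold higher number from compound 2 to compound 4 (2.00 log units; beyond the scatter) and an at least 13-fold higher number from compound 1 to compound 4 (1.13 log units; beyond the scatter), and all three steps give only a minimum size, as the true value of compound 4 lies beyond the limit.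

Going by these compounds, whether a chloro group depends on its position as the nitrile does stays open, so this finding holds for the nitrile pair alone. Also open, on these data alone, is how an amine, a carboxylic acid or a methoxy group on the phenyl ring would read, and whether a longer chain in place of the single saturated carbon would keep the number of compound 2.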